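Pyridyl ether variation and passive membrane permeability

This account rests on a few compounds, and the source may have more. Where it says the series, first, only, none or still open, it means among the compounds named here.

Measured in an ADME assay for permeability, using PAMPA, with a stated time of 4 h; a higher number here means that the compound crosses the layer faster, a lower number that the compound crosses the layer more slowly:
compound 1 `Cn1c(COc2cccc(C(=O)O)c2)nc2ccc(Oc3ccccn3)cc21` gives 2.2 10^-6 cm/s
compound 2 `Cn1c(COc2cccc(C(=O)O)c2)nc2ccc(Oc3ncccc3Cl)cc21` gives 8.1 10^-6 cm/s
compound 3 `Cn1c(COc2cccc(C(=O)O)c2)nc2ccc(Oc3ncccc3F)cc21` gives 3.9 10^-6 cm/s

Compound 3 stands second highest of the three in this assay; its gap to compound 1 is within the scatter, its gap to compound 2 is beyond it. Compound 4 `Cc1cc(F)cnc1Oc1ccc2nc(COc3cccc(C(=O)O)c3)n(C)c2c1` carries 5-fluoro-3-methylpyridin-2-yl in place of 3-fluoropyridin-2-yl on an oxygen on an aromatic ring. The measured steps all concern a single halogen on this ring: a 1.8-fold higher number from compound 1 to compound 3 (0.25 log units; within the scatter), a 3.7-fold higher number from compound 1 to compound 2 (0.57 log units; beyond the scatter) and a 2.1-fold lower number from compound 2 to compound 3 (0.32 log units; beyond the scatter). None covers a methyl or a shifted fluorine, so the bearing on compound 4 is indirect; halogen changes here moved the number modestly, and a small rise or no change beyond the scatter is expected. Compound 4 is estimated at 5 10^-6 cm/s, range 2.5 10^-6 cm/s to 10 10^-6 cm/s. The expected step is a 1.3-fold higher number from compound 3 to compound 4 (0.11 log units; within the scatter).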

Compound 4, apparent permeability: 8.3 10^-6 cm/s
Compound 4: the middle estimate sits 1.7-fold (0.22 log units) below what was measured; measured number inside the range.
By their numbers in this assay, from the lowest: compounds 1 and 3 (each within the scatter of the next); then compounds 2 and 4 (each within the scatter of the next).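

Working from this assay, this position tolerates more than a single halogen: the change from 3-fluoropyridin-2-yl to 5-fluoro-3-methylpyridin-2-yl gives a 2.1-fold higher number from compound 3 to compound 4 (0.33 log units; beyond the scatter), a modest step and the first here to involve a methyl. Against 3-chloropyridin-2-yl the new group gives a 1.0-fold higher number from compound 2 to compound 4 (0.01 log units; within the scatter), so the two cannot be told apart, and against the unsubstituted pyridin-2-yl it gives a 3.8-fold higher number from compound 1 to compound 4 (0.58 log units; beyond the scatter), as large a modest step as the chloro one.

The compounds shown leave open how much of the change belongs to the methyl and how much to the fluorine, and how an amine or a methoxy group on this ring would read. No supporting data bear on what lies behind these steps.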